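The source may report more compounds than this note shows. Statements on the series, on what has been measured and on what is new or still open speak of the compounds shown alone.

In a functional assay on HCT-116 cells (Homo sapiens) for cytotoxicity, read by MTT assay (on this read-out higher numbers stand for weaker inhibition and lower numbers for stronger inhibition), compound 1, with the structure `Cc1cc(S(=O)(=O)N2C(=O)N[C@@H](c3ccccc3)C2C)ccc1NC(=O)c1ccc(N)cc1`, gives > 10000 nM, which is a limit of the assay and not a number. Compound 2, with the structure `Cc1cc(S(=O)(=O)N2C(=O)N[C@@H](c3ccccc3)C2C)ccc1NC(=O)c1ccc([N+](=O)[O-])cc1`, gives > 10000 nM in this assay, again a limit. Within the data shown here, the only measured step, a step that the two limits leave unreadable from compound 1 to compound 2, therefore has no readable size, because of the limit of > 10000 nM in this assay, at which 2 of the 2 values shown sit. Compound 3, with the structure `CC1[C@H](c2ccccc2)NC(=O)N1S(=O)(=O)c1ccc(NC(=O)c2ccc(N)cc2)c(Cl)c1`, differs from compound 1 by chloro in place of methyl on an aromatic carbon. Among the measured compounds shown here, no measured step bears directly on this change. Since the one measured change on the shared core left both values at the limit, as shown by the limit of > 10000 nM in this assay, at which 2 of the 2 values shown sit, the expectation for compound 3 in this assay is a step that the limit leaves unreadable from compound 1 to compound 3 that stays within the scatter. Compound 3 is therefore estimated to give about 15000 nM, with a range from 5000 nM to 50000 nM, most likely again reported only as a limit.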

Compound 3, half-maximal inhibitory concentration: > 10000 nM
Compound 3 gave a limit, no number; the forecaster's own chance of this, stated with the estimate: 75%; the middle value is on the limit's open side.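

The step from compound 1 to compound 3 cannot be read, and neither compound yields a number, because both stand at the same limit of the assay: the limit of > 10000 nM in this assay, at which 3 of the 3 values shown sit. The compounds shown leave open whether chloro in place of methyl changes cytotoxicity in this assay, and which of the three compounds is the more active.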